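Para substituent swap on the shared core: chloro to trifluoromethyl

A few compounds are considered here, and "the series" means these few. Any claim that something is new, unique, unknown or untested is made for them only; others in the source may bear on it.

Compound 3 `NS(=O)(=O)NCC1CCN(c2cc(-c3ccc(Cl)cc3)ncn2)CC1` gives 25500 nM in a functional assay on MCF7 cells (Homo sapiens) for antiproliferative activity, read by sulforhodamine B assay, with a stated time of 48 h; a higher number here means a weaker inhibitor of growth, a lower number a stronger inhibitor of growth. Its two neighbours carry other groups on the same aromatic carbon: compound 1 `CCCCc1ccc(-c2cc(N3CCC(CNS(N)(=O)=O)CC3)ncn2)cc1` gives 21800 nM and compound 2 `COc1ccc(-c2cc(N3CCC(CNS(N)(=O)=O)CC3)ncn2)cc1` gives 35300 nM. The steps among the three, a 1.6-fold higher number from compound 1 to compound 2 (0.21 log units; within the scatter), a 1.2-fold higher number from compound 1 to compound 3 (0.07 log units; within the scatter) and a 1.4-fold lower number from compound 2 to compound 3 (0.14 log units; within the scatter), all fall within the scatter, so on these numbers compound 3 cannot be told apart from either of the other two; compound 1 is nearest to it and compound 2 furthest. Compound 4 `NS(=O)(=O)NCC1CCN(c2cc(-c3ccc(C(F)(F)F)cc3)ncn2)CC1` differs from compound 3 by one change: trifluoromethyl in place of chloro on an aromatic carbon. Going by the values given here, no measured step exchanges chloro for trifluoromethyl directly; the steps that bear on it are the three exchanges on that aromatic carbon just named, none of which moved the number beyond the scatter. The expectation for this assay is therefore no step beyond the scatter, a 1.0-fold lower number from compound 3 to compound 4 (0.01 log units; within the scatter). Compound 4 is estimated at 25000 nM, with a range from 11000 nM to 55000 nM.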

Compound 4, concentration for 50% growth inhibition: 22500 nM
Compound 4: the middle estimate sits 1.1-fold (0.05 log units) above what was measured, and the stated range covers the measured number.
By their numbers in this assay, from the lowest: compounds 1, 4, 3 and 2 (each within the scatter of the next).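

In this assay the three new steps on this aromatic carbon are a 1.1-fold lower number from compound 3 to compound 4 (0.05 log units; within the scatter) and a 1.6-fold lower number from compound 2 to compound 4 (0.20 log units; within the scatter) and also a 1.0-fold higher number from compound 1 to compound 4 (0.01 log units; within the scatter) for the exchange of butyl. Trifluoromethyl, with 4 heavy atoms in place of the single chlorine, therefore extends the earlier picture to a fourth group: no exchange among butyl, methoxy, chloro and trifluoromethyl at this position, para to a large group, moves the number beyond the scatter. No measurement on these compounds offers an explanation for this lack of separation.

As far as these compounds go, whether an amine or a carboxylic acid on this aromatic carbon would give a step beyond the scatter remains open. Also open, from the compounds shown here alone, is whether any change to the sulfamide-bearing chain or elsewhere on the shared core would move the number in this assay series.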